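This account rests on a few compounds, and the source may have more. Where it says the series, first, only, none or still open, it means among the compounds named here.

Compound 1: `CC(C)(N)C(=O)N[C@H](COCc1ccccc1)c1nnnn1CCCc1ccccc1` — 200 nM
Compound 2: `CC(C)(N)C(=O)N[C@H](COCc1ccccc1)c1nnn(Cc2ccccc2NS(C)(=O)=O)n1` — > 5000 nM
Compound 3: `COC(=O)C(c1ccccc1)n1nnc([C@@H](COCc2ccccc2)NC(=O)C(C)(C)N)n1` — > 5000 nM

All three compounds were tested in an assay on isolated protein for displacement of a labelled ligand from growth hormone secretagogue receptor type 1 (Homo sapiens), with a stated time of 1 h; a lower number here means a stronger inhibitor, a higher number a weaker inhibitor. In this assay compound 1 gives 200 nM. For compound 2 the result is only a limit of the assay, > 5000 nM. For compound 3 the result is likewise only a limit, > 5000 nM. Within the data shown here, compound 1 therefore stands as the sole compound with a real number; the other two sit at the limit of > 5000 nM in this assay, at which 2 of the 3 values shown sit. No two of these compounds differ in just one place, so no measured step between them can be read off.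

Compound 4 `COC(=O)CCCn1nnnc1[C@@H](COCc1ccccc1)NC(=O)C(C)(C)N` has not yet been measured. It differs from compound 1 in one place: methoxycarbonyl in place of phenyl on a saturated chain carbon, three bonds along the chain from an aromatic nitrogen. Among the measured compounds shown here, with no measured step of this kind among the compounds seen so far, the expectation leans only on compound 1 and its value of 200 nM. A phenyl ring is removed from the chain and a smaller, more acceptor-rich group takes its place; compound 4 is expected to bind more weakly, with a step of a 7.5-fold higher number from compound 1 to compound 4 (0.88 log units; beyond the scatter) beyond the usual scatter. The estimate for compound 4 in this assay is 1500 nM, with a plausible range from 400 nM to 5000 nM, and a fair chance that the assay reports only a limit.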

Compound 4, inhibition constant: 2380 nM
For compound 4 the middle estimate is 1.6-fold (0.20 log units) below the measured one; low and high end bracket the measured number.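

Going from 3-phenylpropyl to 3-(methoxycarbonyl)propyl gives a 12-fold higher number from compound 1 to compound 4 (1.08 log units; beyond the scatter) in this assay, and this is the first measured step at this place on the chain. It shows that the group carried here has a large influence on the result: with the rest of the molecule unchanged, this one swap moves the number well beyond the usual scatter. Even so, compound 4 still gives a real number rather than only a limit of the assay, so this change weakens binding without pushing the result out of the range the assay can report: the limit of > 5000 nM in this assay, at which 2 of the 4 values shown sit.

A single step cannot separate the loss of the phenyl ring from the arrival of the methoxycarbonyl group, and the shown compounds offer no cause for the change. A cyclohexyl ring in the same place would test whether the ring needs to be aromatic, while a carboxylic acid or an amine on the chain, or a longer or shorter chain carrying the phenyl ring, would show how far each of these features counts.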